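The source may report more compounds than this note shows. Statements on the series, on what has been measured and on what is new or still open speak of the compounds shown alone.

In a functional assay on A549 cells (Homo sapiens) for antiproliferative activity, read by MTT assay, with a stated time of 48 h (a lower number here means a stronger inhibitor, a higher number a weaker inhibitor), compound 1 `CC(=O)OC/C1=C/C[C@](C)(CCC=C(C)C)/C=C/[C@@H](OC(=O)C=C(C)C)[C@](C)(O)/C=C/C1=O`, which carries acetoxy on a saturated chain carbon bound to a double-bonded ring carbon, gives 2950 nM. Among the measured compounds shown here, compound 2 `CCN(CC)C/C1=C/C[C@](C)(CCC=C(C)C)/C=C/[C@@H](OC(=O)C=C(C)C)[C@](C)(O)/C=C/C1=O`, with diethylamino at that place, gives 130 nM, the lower of the two numbers measured so far. Compound 3 `CC(C)=CCC[C@]1(C)/C=C/[C@@H](OC(=O)C=C(C)C)[C@](C)(O)/C=C/C(=O)/C(CN2CCCC2)=C\C1` has not yet been measured. It keeps the shared core and has pyrrolidin-1-yl in place of diethylamino on a saturated chain carbon bound to a double-bonded ring carbon. For the measured compounds named here, only one measured step bears on this change, and only indirectly: a 23-fold lower number from compound 1 to compound 2 (1.36 log units; beyond the scatter), a large step that replaced acetoxy with diethylamino. Going by the values given here, the new change instead exchanges one amino group for another, and no measured pair compares two such groups. No step beyond the scatter is therefore expected, and the expectation stays anchored on compound 2 at 130 nM. The expected change is a 1.2-fold higher number from compound 2 to compound 3 (0.06 log units; within the scatter). For compound 3 the estimated value is 150 nM, with an expected range from 60 nM to 400 nM.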

Compound 3, half-maximal inhibitory concentration: 180 nM
For compound 3 the middle estimate is 1.2-fold (0.08 log units) below the measured one; low and high end bracket the measured number.
By their numbers in this assay, from the lowest: compounds 2 and 3 (each within the scatter of the next); then compound 1.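

In this assay, tying the two ethyl arms of diethylamino into the five-membered ring of pyrrolidin-1-yl, on a saturated chain carbon bound to a double-bonded ring carbon, gives a 1.4-fold higher number from compound 2 to compound 3 (0.14 log units; within the scatter), so this pair shows no measurable separation between the open and the ring-closed amine. The earlier compounds held only one amine at this place, whereas pyrrolidin-1-yl in place of acetoxy now gives a 16-fold lower number from compound 1 to compound 3 (1.21 log units; beyond the scatter), a large step of the same kind as a 23-fold lower number from compound 1 to compound 2 (1.36 log units; beyond the scatter), so the large step is no longer tied to diethylamino alone among the compounds shown. Nothing shown here gives a reason for these numbers.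

The compounds shown leave open whether a larger ring such as piperidin-1-yl, a ring with a second hetero atom such as morpholin-4-yl, or a smaller open amine such as dimethylamino would stay within the scatter of compound 2 and compound 3. They also leave open whether a hydroxy group at this place would read like acetoxy or like the amines.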